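The source may report more compounds than this note shows. Statements on the series, on what has been measured and on what is new or still open speak of the compounds shown alone.

Compound 1 `O=C1C(Nc2ccccc2F)=CC(=O)c2c1nc1n2[C@H]2OC[C@@H](O)[C@H]2OC1` is one of three close analogues that share a core carrying an amine nitrogen with an aromatic group on it. In a functional assay on HeLa cells (Homo sapiens) for inhibition, read by sulforhodamine B assay (on this read-out lower numbers stand for stronger inhibition and higher numbers for weaker inhibition), compound 1 gives 9820 nM. Compound 2 `O=C1C=C(Nc2ccccc2F)C(=O)c2c1nc1n2[C@H]2OC[C@@H](O)[C@H]2OC1` gives 5120 nM, and compound 3 `CCOc1ccccc1NC1=CC(=O)c2nc3n(c2C1=O)[C@H]1OC[C@@H](O)[C@H]1OC3` gives 6040 nM. Compound 1 has the highest of the three numbers, yet its gaps to compound 3 and to compound 2 both lie within the usual scatter, so the three cannot be told apart. For the measured compounds named here, the only single-point step among them, a 1.2-fold higher number from compound 2 to compound 3 (0.07 log units; within the scatter), also stays within the scatter. Compound 4 `O=C1C(NC2CC2)=CC(=O)c2c1nc1n2[C@H]2OC[C@@H](O)[C@H]2OC1` differs from compound 1 by cyclopropyl in place of 2-fluorophenyl on an amine nitrogen. Going by the values given here, no measured step removes the aromatic group itself; the one step that touches it only puts ethoxy in place of fluoro on an aromatic carbon and left the number within the scatter. There is thus no firm ground for expecting a shift in this assay in either direction, and the expected value for compound 4 is 10000 nM, with a range from 3000 nM to 35000 nM. This expectation amounts to a step of a 1.0-fold higher number from compound 1 to compound 4 (0.01 log units; within the scatter).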

Compound 4, half-maximal inhibitory concentration: > 16000 nM
Compound 4: no number, only a limit (the forecaster's own chance of this, stated with the estimate: 25%); at least 1.6-fold (0.20 log units) between middle value and limit.
By their numbers in this assay, from the lowest: compounds 2, 3 and 1 (each within the scatter of the next). At a limit, above all of these: compound 4.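

In this assay compound 4 reaches only a limit of the assay, not a number: the limit of > 16000 nM in this assay, at which 1 of the 4 values shown sits. The step at the amine nitrogen, an at least 1.6-fold higher number from compound 1 to compound 4 (0.21 log units; that floor lies within the scatter), therefore has a floor rather than a size, and that floor alone cannot set the two compounds apart. Still, this is the first change shown that removes the aromatic group from that nitrogen, and the three-membered cyclopropyl ring in its place gives no sign of a lower number, though an aromatic group there is not shown to be required.

On these data alone, it remains open how far beyond its limit compound 4 lies. As far as these compounds go, it is also open whether a butyl chain, a benzyl group or a phenyl ring without fluorine on the same nitrogen would track 2-fluorophenyl or cyclopropyl.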